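Methoxy to hydroxy on compound 1: expected effect

The source may hold more compounds than are shown below. What is called first, only, known or untested is meant among the compounds shown, and "the series" means these compounds.

compound 1, `COc1ccc(C(c2cc3cc(Cl)ccc3o2)n2cncn2)cc1`: > 1000 nM
compound 2, `CC#CCOc1ccc2cc(C(c3ccc(C#N)cc3)n3cncn3)oc2c1`: 0.09 nM
compound 3, `CCC#CCOc1ccc2oc(C(c3ccc(Cl)cc3)n3cncn3)cc2c1`: 21.1 nM

In an assay on JEG-3 cells for inhibition of Aromatase (Homo sapiens), with a stated time of 1 h (on this read-out higher numbers stand for weaker inhibition and lower numbers for stronger inhibition), compound 1 gives only a limit, > 1000 nM, not a number; of the three values shown, one sits there (the limit of > 1000 nM in this assay, at which 1 of the 3 values shown sits). Compound 2 gives 0.09 nM in this assay. Compound 3 gives 21.1 nM in this assay. Among the compounds with values here, compounds 2 and 3 differ from compound 1 in several places at once, so no single step is known here.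

Compound 4, `Oc1ccc(C(c2cc3cc(Cl)ccc3o2)n2cncn2)cc1`, differs from compound 1 by hydrogen in place of methyl on an oxygen on an aromatic ring; that is, hydrogen in place of methyl on an oxygen on an aromatic ring. Within the data shown here, no measured pair isolates this change. With compound 1 known only as a limit, the expected step is a step that the limit leaves unreadable from compound 1 to compound 4, nothing beyond the scatter. Compound 4 is estimated at 2000 nM, within 300 nM to 12000 nM, with a good chance that this assay again reports only a limit.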

Compound 4, half-maximal inhibitory concentration: 30.3 nM
For compound 4 the middle estimate is 66-fold (1.82 log units) above the measured one, and the stated range ends above it.
By their numbers in this assay, from the lowest: compound 2; then compounds 3 and 4 (each within the scatter of the next). At a limit, above all of these: compound 1.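

In this assay, the change from 4-methoxyphenyl to 4-hydroxyphenyl on the shared core gives an at least 33-fold lower number from compound 1 to compound 4 (1.51 log units; beyond the scatter). Within the data shown here, this is the first single-place step, and it shows that the group on this oxygen strongly affects the read-out. Compound 1 is held only as a limit, so the full size of the step stays unknown: the limit of > 1000 nM in this assay, at which 1 of the 4 values shown sits.

Going by these compounds, whether other groups in this place, such as an amine, a carboxylic acid or a longer chain like ethoxy, follow hydroxy or methoxy remains open. Also open, on these data alone, is whether methoxy to hydroxy has a similar effect on other cores.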